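The source may hold more compounds than are shown below. What is called first, only, known or untested is meant among the compounds shown, and "the series" means these compounds.

Measured so far in a functional assay on Caco-2 cells (Homo sapiens) for inhibition, read by MTT assay, with a stated time of 48 h; on this read-out lower numbers stand for stronger inhibition and higher numbers for weaker inhibition: compound 1 `COc1ccccc1-c1csc(N/N=C/c2cc(OC)c(OC)c(Br)c2Br)n1` gives > 100000 nM. Compound 2 `COc1cc(/C=N/Nc2nc(-c3ccc(Br)cc3)cs2)cc(Br)c1OC` gives 36200 nM. Compound 3 `COc1cc(/C=N/Nc2nc(-c3ccc(F)c(F)c3)cs2)c(Br)c(Br)c1OC` gives 22800 nM.

For compound 1 the result is a limit of this assay, not a number (the limit of > 100000 nM in this assay, at which 1 of the 3 values shown sits). Compound 3 holds the lowest of the two real numbers; compound 2 sits within the scatter of it, so no order between these two is claimed. Within the data shown here, the one measured step, an at least 4.3-fold lower number from compound 1 to compound 3 (0.64 log units; beyond the scatter), runs from a limit and reads as at least modest.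

Compound 4 `COc1cc(/C=N/Nc2nc(-c3ccc(Br)cc3)cs2)c(Br)c(Br)c1OC` differs from compound 3 as follows: 4-bromophenyl in place of 3,4-difluorophenyl on an aromatic carbon. Among the measured compounds shown here, no measured step covers this exchange directly; compound 2 also carries 4-bromophenyl and gives 36200 nM, close to compound 3. A step within the scatter is therefore expected in this assay. Compound 4 is estimated at 30000 nM, range 12000 nM to 75000 nM, which means an expected 1.3-fold higher number from compound 3 to compound 4 (0.12 log units; within the scatter).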

Compound 4, half-maximal inhibitory concentration: > 100000 nM
Compound 4 was reported as a limit (the forecaster's own chance of this, stated with the estimate: 10%); middle value at least 3.3-fold (0.52 log units) from the limit.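

At this position on the five-membered aromatic ring, the shared core does not tolerate every aryl group alike: 4-bromophenyl in place of 3,4-difluorophenyl gives an at least 4.3-fold higher number from compound 3 to compound 4 (0.64 log units; beyond the scatter) in these notes. The 4-bromophenyl group alone does not settle the outcome, since bromo in place of hydrogen on an aromatic carbon gives an at least 2.7-fold higher number from compound 2 to compound 4 (0.44 log units; beyond the scatter) on the same aryl background. Compound 4 is a limit in this assay, and its step from compound 1, also a limit, cannot be read: the limit of > 100000 nM in this assay, at which 2 of the 4 values shown sit.

On these data alone, whether the 4-bromophenyl and bromo changes act independently remains open. So does whether an amine or a carboxylic acid on the phenyl ring at this position would return a real number.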